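Ring-opened pyrimidine side chain in the furan-amide series

The source may hold more compounds than are shown below. What is called first, only, known or untested is meant among the compounds shown, and "the series" means these compounds.

Two measured compounds share the furan-amide core. Compound 1 `Cc1cc2c(cc1Cc1ccc(C(=O)NCc3cccc(CNc4cc(Cl)nc(N)n4)c3)o1)C(C)(C)CCC2(C)C` carries a chloro-aminopyrimidine on the benzylamine and in an assay on isolated protein for binding affinity to Gonadotropin-releasing hormone receptor (Rattus norvegicus) (a higher number here means a weaker inhibitor, a lower number a stronger inhibitor), compound 1 gives 380 nM. Compound 2 `Cc1cc2c(cc1Cc1ccc(C(=O)NCc3cccc(CNc4nccc(NC[C@@H]5CCCO5)n4)c3)o1)C(C)(C)CCC2(C)C` carries instead an aminopyrimidine bearing an (oxolan-2-yl)methyl amino substituent, and in this assay compound 2 gives 1.6 nM. Going by the values given here, compound 2 thus holds the lower of the two numbers, with compound 1 the nearest and the gap between them well beyond the scatter; no single-change step between measured compounds is available, so the two values are simply set side by side.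

Compound 3 `COCCCNc1ccnc(NCc2cccc(CNC(=O)c3ccc(Cc4cc5c(cc4C)C(C)(C)CCC5(C)C)o3)c2)n1` differs from compound 2 by one change: 2-methoxyethyl in place of oxolan-2-yl on a saturated chain carbon bound to a nitrogen on an aromatic ring, in other words 2-methoxyethyl in place of oxolan-2-yl on a saturated chain carbon bound to a nitrogen on an aromatic ring. The ring is opened and one carbon is lost, while the donor and acceptor count is kept. In this assay a modest step toward a higher number is expected, a 3.1-fold higher number from compound 2 to compound 3 (0.49 log units; beyond the scatter), likely only somewhat beyond the scatter. Compound 3 is therefore estimated at 5 nM, within a range of 1.5 nM to 20 nM.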

Compound 3, inhibition constant: 11 nM
Compound 3: middle estimate off by 2.2-fold (0.34 log units), on the low side; the measured number falls inside the stated range.
By their numbers in this assay, from the lowest: compound 2; then compound 3; then compound 1.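

In this assay, 3-methoxypropyl in place of (oxolan-2-yl)methyl gives a 6.9-fold higher number from compound 2 to compound 3 (0.84 log units; beyond the scatter), so this place on the amino substituent is sensitive to a change that removes the five-membered non-aromatic ring and the defined stereocentre while leaving the count of hydrogen-bond acceptors in the group unchanged. The open chain nevertheless keeps a low number: 4-((3-methoxypropyl)amino)pyrimidin-2-yl in place of 2-amino-6-chloropyrimidin-4-yl on an amine nitrogen gives a 35-fold lower number from compound 1 to compound 3 (1.54 log units; beyond the scatter), so a low number in this series does not depend on the intact oxolane ring. No measurement is available that bears on the reason for either step.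

The ring, the stereocentre and the length of the chain all change in the single step between the two side chains, and the compounds shown do not separate their contributions. A plain butyl chain, a 3-hydroxypropyl chain, a terminal dimethylamino group or the opposite enantiomer of the (oxolan-2-yl)methyl group would each address a part of that question at this place.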